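Swapping the pyrimidine for a quinoxaline on a sulfonamide

The compounds below may be only part of what the source reports. "The series", "measured", "known", "first", "only" and "open" are said of these compounds alone.

Of the compounds shown here, two sharing one core have been measured in a functional assay on T47D cells (Homo sapiens) for cytotoxicity, read by sulforhodamine B assay, with a stated time of 48 h; a lower number here means a stronger inhibitor, a higher number a weaker inhibitor. Compound 1 `NS(=O)(=O)c1ccc(N/C=C\C(=O)c2cc3ccccc3oc2=O)cc1` carries a bare sulfonamide and gives 109000 nM. For the measured compounds named here, compound 2 `Cc1ccnc(NS(=O)(=O)c2ccc(N/C=C\C(=O)c3cc4ccccc4oc3=O)cc2)n1`, which places an aromatic ring on the sulfonamide nitrogen, gives 24500 nM, the lowest of the two numbers; the only step available, a 4.4-fold lower number from compound 1 to compound 2 (0.65 log units; beyond the scatter), is a modest one in the direction of stronger inhibition. Compound 3 `O=C(/C=C\Nc1ccc(S(=O)(=O)Nc2cnc3ccccc3n2)cc1)c1cc2ccccc2oc1=O` is the next candidate, and it differs from compound 2 in one place: quinoxalin-2-yl in place of 4-methylpyrimidin-2-yl on a sulfonamide nitrogen. Going by the values given here, no measured pair shows one such ring exchanged for another, so the step from compound 1 to compound 2 can only hint that a ring at this position, rather than hydrogen, has so far gone with the lower number. The change to compound 3 keeps a ring there, so the step of a 1.2-fold lower number from compound 2 to compound 3 (0.09 log units; within the scatter) is expected to stay within the scatter, with no clear direction. Compound 3 is therefore estimated at 20000 nM, in a range from 7000 nM to 60000 nM.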

Compound 3, half-maximal inhibitory concentration: 86900 nM
For compound 3 the middle estimate is 4.3-fold (0.64 log units) below the measured one, outside the stated range (above it).
By their numbers in this assay, from the lowest: compound 2; then compounds 3 and 1 (each within the scatter of the next).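

In this assay the identity of the ring on the sulfonamide nitrogen turns out to matter, not just its presence: quinoxalin-2-yl in place of 4-methylpyrimidin-2-yl gives a 3.5-fold higher number from compound 2 to compound 3 (0.55 log units; beyond the scatter) and so moves the number by more than repeat measurements would. Set against the bare sulfonamide, the same ring gives a 1.3-fold lower number from compound 1 to compound 3 (0.10 log units; within the scatter) and so leaves the number level with that of the hydrogen compound. The earlier hint that a ring here goes with a lower number therefore rests on compound 2 alone, and compound 3 goes against it.

The two rings differ in more than one feature, since quinoxalin-2-yl brings an added six-membered aromatic ring of carbon only and 4-methylpyrimidin-2-yl brings a methyl group, so the compounds shown cannot tell which feature accounts for the step, and a pyrimidin-2-yl without the methyl, a phenyl ring or a thiazole ring on this nitrogen would help to separate them. Nothing given here explains why compound 2 stands apart from the other two.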